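Swapping the amide substituent and expected cytotoxicity

This account rests on a few compounds, and the source may have more. Where it says the series, first, only, none or still open, it means among the compounds named here.

In an ADME assay on HepG2 2.2.15 cells (Homo sapiens) for cytotoxicity, read by MTT assay, with stated times of 48 h and 9 days (on this read-out lower numbers stand for higher toxicity in this test and higher numbers for lower toxicity in this test), compound 2 `COc1ccc2c(=O)c(/C=C/C(=O)NCc3ccc(C)cc3)coc2c1` gives 257000 nM, the lowest of the two numbers measured, while compound 1 `COc1ccc2c(=O)c(/C=C/C(=O)Nc3cc(C)ccc3C)coc2c1` gives 1100000 nM. Among the measured compounds shown here, the one measured step, a 4.3-fold lower number from compound 1 to compound 2 (0.63 log units; beyond the scatter), shows that replacing a ring-bound amide substituent by a benzyl-type one lowered the number. Compound 3 `CCOc1ccc(NC(=O)/C=C/c2coc3cc(OC)ccc3c2=O)cc1` differs from compound 2 by 4-ethoxyphenyl in place of 4-methylbenzyl on an amide-type nitrogen, which returns to a ring joined directly to the nitrogen, resembling compound 1. A partial reversal of that step is therefore expected, with a 2.3-fold higher number from compound 2 to compound 3 (0.37 log units; beyond the scatter) in this assay. Compound 3 is estimated at 600000 nM, within 200000 nM to 2000000 nM.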

Compound 3, half-maximal cytotoxic concentration: 460000 nM
Compound 3: the middle estimate sits 1.3-fold (0.12 log units) above what was measured; the range from low to high includes it.
By their numbers in this assay, from the lowest: compounds 2 and 3 (each within the scatter of the next); then compound 1.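

In this assay the change shows as a 1.8-fold higher number from compound 2 to compound 3 (0.25 log units; within the scatter) so 4-ethoxyphenyl and 4-methylbenzyl on an amide-type nitrogen cannot be told apart here, and a ring joined directly to that nitrogen does not by itself restore the number of compound 1. The choice of directly joined ring does matter, with 4-ethoxyphenyl in place of 2,5-dimethylphenyl giving a 2.4-fold lower number from compound 1 to compound 3 (0.38 log units; beyond the scatter) as the step. Nothing available explains these differences. On these data alone, whether a group carrying an amine or a carboxylic acid, or a longer chain, on that nitrogen would shift the number stays open.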